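The source may report more compounds than this note shows. Statements on the series, on what has been measured and on what is new or still open speak of the compounds shown alone.

Working notes on the series. The read-out for the two measured compounds is an ADME assay on microsomes from liver (Rattus norvegicus) for metabolic stability, with a stated time of 10 min; on this read-out lower numbers stand for a less stable compound and higher numbers for a more stable compound. Compound 1, `CCCCCNc1nc(Nc2ccc([N+](=O)[O-])cc2)nc(OCC(F)(F)F)n1`, is the low point so far: in this assay compound 1 gives 35%. Compound 2, `O=C(NS(=O)(=O)c1ccccc1)c1ccc(Nc2nc(NC3(c4ccc(Cl)cc4)CC3)nc(OCC(F)(F)F)n2)cc1`, stands at the top of the two numbers: in this assay compound 2 gives 100%, which lies beyond the scatter above compound 1. Among the measured compounds shown here, no pair that differs in one place has been measured, so the two values show only where the pair stands, not what any single change does.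

Compound 3, `COC(=O)NCCS(=O)(=O)NC(=O)c1ccc(Nc2nc(NC3(c4ccc(Cl)cc4)CC3)nc(OCC(F)(F)F)n2)cc1`, differs from compound 2 in one place: 2-((methoxycarbonyl)amino)ethyl in place of phenyl on a sulfonyl sulfur. The remainder of the two structures is shared. Compound 2 already sits at the full-recovery end of the read-out, so the step can only run downward or stay flat. With compound 2 at 100% as the only anchor, the expectation for compound 3 is a step of a number 15 percentage points lower from compound 2 to compound 3 (beyond the scatter), most likely within or just beyond the scatter. The estimate for compound 3 in this assay is 85%, with a range from 60% to 100%.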

Compound 3, percent of the compound remaining: 100%
Compound 3: middle estimate off by 15 percentage points, on the low side; measured number inside the range.
By their numbers in this assay, from the lowest: compound 1; then compounds 2 and 3 (each within the scatter of the next).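

In this assay, among the compounds shown here, 2-((methoxycarbonyl)amino)ethyl in place of phenyl on a sulfonyl sulfur gives no change at the digits printed from compound 2 to compound 3 (within the scatter), the first step that can be read at a single place. This position therefore accepts a chain with no ring, carrying a hydrogen-bond donor and two hydrogen-bond acceptors, in place of an aromatic ring of carbon only, and the read-out does not tell the two groups apart. Both values lie at the full-recovery end of the read-out. Any difference that lies beyond its top end would stay hidden in this step. No measured evidence bears on the reason for this result.

Still open, on these data alone, is whether a small group such as methyl, a longer alkyl chain, or a chain ending in a carboxylic acid or a free amine on the same sulfonyl sulfur would also stay at this end of the read-out. Also open, as far as these compounds go, is whether the same exchange would read the same way on a different core, where the values do not start from the full-recovery end.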